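The source may hold more compounds than are shown below. What is called first, only, known or untested is meant among the compounds shown, and "the series" means these compounds.

Compound 1 `Cc1nn(-c2ncnc3nc[nH]c23)c2c1C(OCCc1ccccc1)CC(=O)N2`: 40 nM
Compound 2 `Cc1nn(-c2ncnc3nc[nH]c23)c2c1C(C(=O)NCc1ccc(F)cc1)CC(=O)N2`: 1220 nM
Compound 3 `Cc1nn(-c2ncnc3nc[nH]c23)c2c1C(C(=O)N(C)c1ccccc1)CC(=O)N2`: 5220 nM

In a functional assay on HEK293 cells for agonist activity at G-protein coupled receptor 39 (Homo sapiens), read by scintillation proximity assay and inositol phosphate accumulation, with a stated time of 75 min (a lower number here means that less compound is needed, a higher number that more compound is needed for the effect), compound 1 gives the lowest of the three numbers; compound 2 is nearest to it and compound 3 furthest, the step of a 130-fold higher number from compound 1 to compound 3 (2.12 log units; beyond the scatter) being large. The step of a 4.3-fold higher number from compound 2 to compound 3 (0.63 log units; beyond the scatter) is modest. Compound 4 `COc1ccc(CCOC2CC(=O)Nc3c2c(C)nn3-c2ncnc3nc[nH]c23)cc1` differs from compound 1 by methoxy in place of hydrogen on an aromatic carbon. Going by the values given here, neither measured step bears directly on this change: both alter the group on the saturated ring carbon or the amide, and no measured pair differs only by a substituent on the phenyl. With nothing to indicate movement, a step within the usual scatter is expected, no change at the digits printed from compound 1 to compound 4 (within the scatter). Compound 4 is therefore estimated at 40 nM, range 15 nM to 120 nM, in this assay.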

Compound 4, half-maximal effective concentration: 70 nM
The estimate for compound 4 lay 1.8-fold (0.24 log units) below the measured number; the range from low to high includes it.
By their numbers in this assay, from the lowest: compounds 1 and 4 (each within the scatter of the next); then compound 2; then compound 3.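

In this assay methoxy in place of hydrogen on an aromatic carbon, para to a large group, gives a 1.8-fold higher number from compound 1 to compound 4 (0.24 log units; within the scatter) and so leaves the number within the scatter. Going by these compounds alone, this is the only reading here of a substituent on that phenyl ring, as the earlier steps changed the group on the saturated ring carbon or on the carbonyl carbon. No measurement shown gives a reason for this result. On these data alone, whether a carboxylic acid or a dimethylamino group in the same place would also stay within the scatter remains open.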